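The source may report more compounds than this note shows. Statements on the series, on what has been measured and on what is new or still open speak of the compounds shown alone.

Measured compounds:
- compound 1, `Cn1ccnc1S(=O)(=O)CCCSc1nc(-c2ccccc2)c(-c2ccccc2)[nH]1` — 11 nM
- compound 2, `Cn1ccnc1SCCCCSc1nc(-c2ccccc2)c(-c2ccccc2)[nH]1` — 38 nM
- compound 3, `c1ccc(-c2nc(SCCCCCSc3ncc[nH]3)[nH]c2-c2ccccc2)cc1` — 44 nM

These three compounds share a core and differ only in the chain that hangs from its sulfur and in the heterocycle at the end of that chain. In an assay for inhibition of sterol O-acyltransferase 1 (Rattus norvegicus) (on this read-out lower numbers stand for stronger inhibition and higher numbers for weaker inhibition), compound 3 gives the highest of the three numbers. Its neighbour is compound 2, with a difference that stays within the scatter, so the two cannot be ranked; the step of a 4.0-fold higher number from compound 1 to compound 3 (0.60 log units; beyond the scatter) is beyond the scatter, as is a 3.5-fold higher number from compound 1 to compound 2 (0.54 log units; beyond the scatter).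

Compound 4, `c1ccc(-c2nc(SCCCCCn3cccn3)[nH]c2-c2ccccc2)cc1`, is not yet measured. It differs from compound 3 by 1H-pyrazol-1-yl in place of (1H-imidazol-2-yl)sulfanyl on a saturated chain carbon, five bonds along the chain from a sulfur. Among the measured compounds shown here, no measured step tests this exact exchange: the steps from compound 1 involve a sulfonyl-to-sulfanyl change, and the step of a 1.2-fold higher number from compound 2 to compound 3 (0.06 log units; within the scatter) shows that altering the imidazole and shifting the chain left the number within the scatter. Exchanging the terminal heterocycle therefore seems unlikely to move the number far. Compound 4 is expected to give about 70 nM, between 25 nM and 200 nM, which means a step of a 1.6-fold higher number from compound 3 to compound 4 (0.20 log units; within the scatter) that is estimated to stay near the scatter.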

Compound 4, half-maximal inhibitory concentration: 24 nM
Compound 4: the middle estimate sits 2.9-fold (0.46 log units) above what was measured; measured number below the stated range.
By their numbers in this assay, from the lowest: compound 1; then compounds 4, 2 and 3 (each within the scatter of the next).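

In this assay, among the compounds shown here, the step of a 1.8-fold lower number from compound 3 to compound 4 (0.26 log units; within the scatter) shows that this position tolerates a larger exchange than the earlier compounds tested: the sulfanyl link and the imidazole both leave, 1H-pyrazol-1-yl enters on the saturated chain carbon, and the change, with 1 hydrogen-bond donor leaving and 0 entering, stays within the scatter. The step of a 1.6-fold lower number from compound 2 to compound 4 (0.20 log units; within the scatter) also stays within the scatter, whereas the step of a 2.2-fold higher number from compound 1 to compound 4 (0.34 log units; beyond the scatter) lies beyond it, so the sulfonyl compound remains alone at the low end of the numbers, with the other three not separable from their nearest neighbours. Nothing shown here explains why these changes have so little effect on the number.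

The compounds shown leave open whether the sulfonyl group or the chain length sets compound 1 apart, since the two differ together in every step from that compound. They also leave open how 1H-pyrazol-1-yl would behave on a shorter or longer chain, and whether a simple end group such as an amine or a carboxylic acid would fit at this position as well as the two-nitrogen rings do.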